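Bromo shift from compound 3 to compound 4

The source may hold more compounds than are shown below. What is called first, only, known or untested is meant among the compounds shown, and "the series" means these compounds.

In an ADME assay on HEK293 cells (Homo sapiens) for cytotoxicity, read by reporter gene assay and resazurin assay, with a stated time of 48 h (a higher number here means that more compound is tolerated, a lower number that less compound is tolerated), compound 1 `COc1c(Br)cccc1C(=O)Nc1ccc(Sc2nc3ccccc3s2)cc1` gives > 100000 nM, which is a limit of the assay. Compound 2 `O=C(Nc1ccc(Sc2nc3ccccc3s2)cc1)c1ccccc1O` gives 74000 nM, and compound 3 `O=C(Nc1ccc(Sc2nc3ccccc3s2)cc1)c1cccc(Br)c1O` gives 71000 nM. Compound 3 thus stands level with compound 2, and the only other result is a limit.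

Compound 4 `O=C(Nc1ccc(Sc2nc3ccccc3s2)cc1)c1cc(Br)ccc1O` has the same atoms as compound 3, joined differently: 5-bromo-2-hydroxyphenyl in place of 3-bromo-2-hydroxyphenyl on a carbonyl carbon. 5-bromo-2-hydroxyphenyl replaces 3-bromo-2-hydroxyphenyl on a carbonyl carbon whose other neighbour is an amide-type nitrogen.

The closest measured evidence is a 1.0-fold lower number from compound 2 to compound 3 (0.02 log units; within the scatter), for bromo in place of hydrogen. The steps of an at least 1.3-fold lower number from compound 1 to compound 2 (0.13 log units; that floor lies within the scatter) and an at least 1.4-fold lower number from compound 1 to compound 3 (0.14 log units; that floor lies within the scatter) start from the limit and give only floors. Within the data shown here, no measured step covers 5-bromo-2-hydroxyphenyl itself, so the expectation remains loose. In this assay no change beyond the scatter is expected, because the step of a 1.0-fold lower number from compound 2 to compound 3 (0.02 log units; within the scatter) stayed within it. The expected step is a 1.3-fold lower number from compound 3 to compound 4 (0.11 log units; within the scatter). The estimate for compound 4 is 55000 nM, with an expected range of 22000 nM to 100000 nM.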

Compound 4, half-maximal cytotoxic concentration: 42000 nM
Beside the measured number, compound 4's estimate is 1.3-fold (0.12 log units) above it; the range from low to high includes it.
By their numbers in this assay, from the lowest: compounds 4, 3 and 2 (each within the scatter of the next). At a limit, above all of these: compound 1.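

Neither a 1.7-fold lower number from compound 3 to compound 4 (0.23 log units; within the scatter) nor a 1.8-fold lower number from compound 2 to compound 4 (0.25 log units; within the scatter) leaves the scatter, so in this assay 5-bromo-2-hydroxyphenyl on the carbonyl carbon cannot be told apart from 3-bromo-2-hydroxyphenyl or from the unbrominated group of compound 2. Among these compounds, what is new is an at least 2.3-fold lower number from compound 1 to compound 4 (0.37 log units; beyond the scatter), the first step to pass the scatter, and it does so only as a floor. On these data alone, compound 1 gives a limit and not a number, so the true size of that step stays unknown: the limit of > 100000 nM in this assay, at which 1 of the 4 values shown sits.

As far as these compounds go, whether an amine or a carboxylic acid in place of the bromo would move the tolerated concentration beyond the scatter remains open. Also open, from the compounds shown here alone, is how much lower the number of compound 4 really lies than that of compound 1.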